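Aryl substitution on the ring nitrogen of the shared core

This account rests on a few compounds, and the source may have more. Where it says the series, first, only, none or still open, it means among the compounds named here.

Measured in a functional assay on A549 cells (Homo sapiens) for antiproliferative activity, read by MTT assay, with a stated time of 72 h; on this read-out higher numbers stand for weaker inhibition and lower numbers for stronger inhibition:
Compound 1 `O=C(Nc1ccc(Oc2ccnc3[nH]ccc23)cc1)c1cc2cccnc2n(-c2ccc(F)cc2)c1=O` gives 210 nM.
Compound 2 `O=C(Nc1ccc(Oc2ccnc3[nH]ccc23)cc1)c1cc2cccnc2n(-c2ccc(Br)cc2F)c1=O` gives 1570 nM.
Compound 3 `O=C(Nc1ccc(Oc2ccnc3[nH]ccc23)c(F)c1)c1cc2cccnc2n(-c2ccc(F)cc2)c1=O` gives 62 nM.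

Compound 3 stands lowest of the three and shows the strongest inhibition; compound 1 is nearest (a 3.4-fold lower number from compound 1 to compound 3 (0.53 log units; beyond the scatter)) and compound 2 furthest. Compound 4 `O=C(Nc1ccc(Oc2ccnc3[nH]ccc23)c(F)c1)c1cc2cccnc2n(-c2ccc(C(F)(F)F)cc2Cl)c1=O` differs from compound 3 in one place: 2-chloro-4-(trifluoromethyl)phenyl in place of 4-fluorophenyl on an aromatic nitrogen. Among the measured compounds shown here, one measured step bears on this change, a 7.5-fold higher number from compound 1 to compound 2 (0.87 log units; beyond the scatter), likewise a substituted phenyl in place of 4-fluorophenyl on the aromatic nitrogen. The fluoro on an aromatic carbon shared by compounds 3 and 4 has been tested once only, and nothing shows how it behaves combined with a change on the aromatic nitrogen. A step of the same direction and similar size is therefore expected in this assay, a 6.5-fold higher number from compound 3 to compound 4 (0.81 log units; beyond the scatter). For compound 4 the expected value is 400 nM, with a range from 130 nM to 1300 nM.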

Compound 4, half-maximal inhibitory concentration: 1020 nM
Beside the measured number, compound 4's estimate is 2.6-fold (0.41 log units) below it; the measured number falls inside the stated range.
By their numbers in this assay, from the lowest: compound 3; then compound 1; then compounds 4 and 2 (each within the scatter of the next).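

In this assay, replacing 4-fluorophenyl on the aromatic nitrogen with 2-chloro-4-(trifluoromethyl)phenyl gives a 16-fold higher number from compound 3 to compound 4 (1.22 log units; beyond the scatter). This extends the rise seen with compound 2 to a second substituted phenyl and to the fluoro-bearing compound 3, so the fluoro does not prevent a rise at this position. No available evidence accounts for the step.

Still open, from the compounds shown here alone, is the separate contribution of the 2-chloro and 4-trifluoromethyl groups, which 2-chlorophenyl and 4-(trifluoromethyl)phenyl would address. Unsubstituted phenyl or an aliphatic amine-bearing chain at this nitrogen also remains open.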